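Para-substituent swap on the aryl-thiazole: bromo to trifluoromethyl

The compounds below may be only part of what the source reports. "The series", "measured", "known", "first", "only" and "open" are said of these compounds alone.

Measured compounds:
- compound 1 `COc1ccc(C2=NN(c3nc(-c4ccc(Br)cc4)cs3)C(c3cccs3)C2)cc1`: 21200 nM
- compound 2 `COc1ccc(C2=NN(c3nc(-c4ccc(OC)cc4)cs3)C(c3cccs3)C2)cc1`: 16200 nM

In a functional assay on MCF7 cells (Homo sapiens) for antiproliferative activity, read by MTT assay, with a stated time of 48 h (on this read-out lower numbers stand for stronger inhibition and higher numbers for weaker inhibition), compound 1 gives 21200 nM and stands at the highest of the two numbers recorded so far; its nearest neighbour is compound 2, and the step of a 1.3-fold lower number from compound 1 to compound 2 (0.12 log units; within the scatter) is within the scatter. Compound 3 `COc1ccc(C2=NN(c3nc(-c4ccc(C(F)(F)F)cc4)cs3)C(c3cccs3)C2)cc1` is the next member awaiting measurement in this assay. It differs from compound 1 by trifluoromethyl in place of bromo on an aromatic carbon. Going by the values given here, the one step that bears on this place is the change from compound 1 to compound 2, where a different group at the same aromatic carbon left the number within the scatter. Nothing measured points to a move beyond the scatter in this assay, so the step of a 1.1-fold lower number from compound 1 to compound 3 (0.03 log units; within the scatter) is expected to be small. Compound 3 is therefore estimated at 20000 nM, with a range from 8000 nM to 50000 nM.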

Compound 3, half-maximal inhibitory concentration: 45700 nM
Estimate against measurement, compound 3: 2.3-fold (0.36 log units) below; low and high end bracket the measured number.
By their numbers in this assay, from the lowest: compounds 2 and 1 (each within the scatter of the next); then compound 3.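

In this assay the aromatic carbon carrying the bromo group of compound 1 proves not to be indifferent to substitution: the step of a 2.2-fold higher number from compound 1 to compound 3 (0.33 log units; beyond the scatter) and the step of a 2.8-fold higher number from compound 2 to compound 3 (0.45 log units; beyond the scatter) are both modest but lie beyond the scatter, while bromo and methoxy alone could not be told apart. Among these three compounds, compound 3 is therefore the weakest, and trifluoromethyl is the first group at this place to shift the number measurably. No evidence on the origin of this shift is available for the series.

On these data alone, whether the shift is particular to trifluoromethyl or extends to other groups at this carbon remains open. An amine or a carboxylic acid here would show whether any group can move the number below those of compound 1 and compound 2.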